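Hydroxy on the Saturated Ring in Two Naphthalene Series

A few compounds are considered here, and "the series" means these few. Any claim that something is new, unique, unknown or untested is made for them only; others in the source may bear on it.

Compound 1 `C=C1CC[C@@H]2[C@](C)(CCC[C@]2(C)C(=O)OC)[C@H]1CCc1ccc2c(OC(C)=O)ccc(OC(C)=O)c2c1` and compound 3 `C=C1[C@H](O)C[C@@H]2[C@](C)(CCC[C@]2(C)C(=O)OC)[C@H]1CCc1ccc2c(OC(C)=O)ccc(OC(C)=O)c2c1` share a core and are both measured in a functional assay on HT-29 cells (Homo sapiens) for cytotoxicity, read by sulforhodamine B assay, with a stated time of 72 h; on this read-out higher numbers stand for weaker inhibition of growth and lower numbers for stronger inhibition of growth. In this assay compound 1 gives 500 nM, and compound 3 gives 1000 nM. The change between them is hydroxy in place of hydrogen on a saturated ring carbon, and it produced a 2.0-fold higher number from compound 1 to compound 3 (0.30 log units; within the scatter). Compound 2 `C=C1CC[C@@H]2[C@](C)(CCC[C@]2(C)C(=O)OC)[C@H]1CCc1ccc2c(OCc3ccccc3)ccc(OCc3ccccc3)c2c1` carries a different core; the difference between the two cores is not broken down here. In this assay compound 2 gives only a limit, > 5000 nM, which is the limit of > 5000 nM in this assay, at which 1 of the 3 values shown sits. Compound 4 `C=C1CC[C@@H]2[C@](C)(CCC[C@]2(C)C(=O)OC)[C@]1(O)CCc1ccc2c(OCc3ccccc3)ccc(OCc3ccccc3)c2c1` has not yet been measured in this assay. It differs from compound 2 by hydroxy in place of hydrogen on a saturated ring carbon, the same kind of change as from compound 1 to compound 3, though the surroundings of the place are not the same: in compound 4 the carbon is next to the ring atom that bears a fused ring and next to the ring atom that bears a methyl group. The expected step is a step that the limit leaves unreadable from compound 2 to compound 4, resting on compound 2 having given only the limit > 5000 nM and on the step of a 2.0-fold higher number from compound 1 to compound 3 (0.30 log units; within the scatter). Compound 4 is therefore expected to give about 9000 nM, between 4000 nM and 25000 nM.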

Compound 4, concentration for 50% growth inhibition: 12400 nM
The estimate for compound 4 lay 1.4-fold (0.14 log units) below the measured number; the range from low to high includes it.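

Among these compounds, no step from compound 2 to compound 4 can be read in this assay, since compound 2 gives only a limit and not a number: the limit of > 5000 nM in this assay, at which 1 of the 4 values shown sits. The compounds shown leave open how much hydroxy in place of hydrogen on a saturated ring carbon changes growth inhibition on the core of compound 2.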